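Moving the methyl on the pyridine of a thiosemicarbazide

The compounds below may be only part of what the source reports. "The series", "measured", "known", "first", "only" and "open" are said of these compounds alone.

The series is small. Compound 1 `Cc1cccc(/C(N)=N/NC(=S)N2CCN(c3ccccn3)CC2)n1` carries a 6-methylpyridin-2-yl group on its amidine carbon and a piperazine bearing a pyridine on the thiourea; in a functional assay on A-431 cells (Homo sapiens) for cytotoxicity, read by MTT assay, with a stated time of 72 h, tested at 30 uM (on this read-out lower numbers stand for less inhibition of growth and higher numbers for more inhibition of growth at the one concentration tested), compound 1 gives 57.4%. This is the lowest of the three numbers. Compound 2 `Cc1ccnc(/C(N)=N/NC(=S)N2CCOCC2)c1` in this assay gives 74.6%, a value beyond the scatter above that of compound 1, and compound 3 `N/C(=N\NC(=S)N1CCCC1)c1ccc(F)cn1` gives 83.3%, the furthest from compound 1 and also beyond the scatter. No pair among these three differs in one place only, so no single step can be read from them.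

Compound 4 `Cc1ccnc(/C(N)=N/NC(=S)N2CCN(c3ccccn3)CC2)c1` has not been measured. It differs from compound 1 by 4-methylpyridin-2-yl in place of 6-methylpyridin-2-yl on a carbon with a double bond to nitrogen, so the atoms are the same and only the methyl has moved on the ring. Compound 2, which shares the 4-methylpyridin-2-yl group but has a different thiourea amine, gives 74.6%, and this is taken as a loose guide. The step from compound 1 to compound 4 is expected to be a number 8.6 percentage points higher from compound 1 to compound 4 (within the scatter), an increase that may or may not exceed the scatter. Compound 4 is thus estimated at 66%, with a range from 46% to 84%.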

Compound 4, percent growth inhibition at one concentration: 65.7%
Compound 4: the middle estimate sits 0.3 percentage points above what was measured; low and high end bracket the measured number.
By their numbers in this assay, from the lowest: compounds 1, 4, 2 and 3 (each within the scatter of the next, the first and the last beyond it).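

Exchanging 6-methylpyridin-2-yl for 4-methylpyridin-2-yl on a carbon with a double bond to nitrogen gives, in this assay, a number 8.3 percentage points higher from compound 1 to compound 4 (within the scatter). Among these compounds, this is the first change that can be read at a single place, and with the rest of the structure held constant, moving the methyl leaves compound 1 and compound 4 within the scatter of each other on this read-out. No measured property of either compound bears on this result.

The compounds shown leave open whether moving the methyl has the same outcome with the thiourea amine of compound 2 or compound 3. Also open, from the compounds shown here alone, is how an ethyl or a methoxy group in place of the methyl, or an unsubstituted pyridin-2-yl group, would compare in this assay.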